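Compound 2 to compound 4 on the triple-bonded carbon

The source may hold more compounds than are shown below. What is called first, only, known or untested is meant among the compounds shown, and "the series" means these compounds.

Going by the values given here, in a functional assay on MDA-MB-231 cells (Homo sapiens) for antiproliferative activity, read by WST assay, with a stated time of 72 h (on this read-out lower numbers stand for stronger inhibition of growth and higher numbers for weaker inhibition of growth), compound 2 (`N=C(N)c1ccc(/N=N/Nc2cccc(C#Cc3ccccn3)c2)cc1`) gives 14400 nM and stands second highest of the three numbers so far. Compound 1 (`C#Cc1cccc(N/N=N/c2ccc(C(=N)N)cc2)c1`) gives 20500 nM and lies within the scatter of compound 2, while compound 3 (`N=C(N)c1ccc(/N=N/Nc2ccccc2C#Cc2ccccc2)cc1`) gives 5100 nM and lies lower than compound 2, beyond the scatter.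

Compound 4 (`COc1ccc(C#Cc2cccc(N/N=N/c3ccc(C(=N)N)cc3)c2)cc1`) has not been measured. Its change from compound 2 is 4-methoxyphenyl in place of pyridin-2-yl on a triple-bonded carbon. Among the compounds with values here, one measured step bears on that carbon: a 1.4-fold lower number from compound 1 to compound 2 (0.15 log units; within the scatter) (pyridin-2-yl in place of hydrogen on a triple-bonded carbon) and it stays within the scatter. Within the data shown here, no measured step exchanges one group on that carbon for another. Among the measured compounds shown here, no single-place step ties compound 3 to the others, so its number sets no size for this change.

In this assay no step beyond the scatter is therefore expected, and the direction is not firmly indicated. a 1.3-fold lower number from compound 2 to compound 4 (0.12 log units; within the scatter) is the estimated step and it is expected to stay inside the scatter. For compound 4 the expected value is 11000 nM within an estimated range from 5000 nM to 25000 nM in these growth measurements.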

Compound 4, concentration for 50% growth inhibition: 5500 nM
Compound 4: middle estimate off by 2.0-fold (0.30 log units), on the high side; the range from low to high includes it.
By their numbers in this assay, from the lowest: compounds 3 and 4 (each within the scatter of the next); then compounds 2 and 1 (each within the scatter of the next).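

In this assay the triple-bonded carbon now gives its first steps beyond the scatter, with a 2.6-fold lower number from compound 2 to compound 4 (0.42 log units; beyond the scatter) as an exchange of one aromatic ring for another and a 3.7-fold lower number from compound 1 to compound 4 (0.57 log units; beyond the scatter) as a replacement of hydrogen, both of modest size. The earlier step on this carbon, a 1.4-fold lower number from compound 1 to compound 2 (0.15 log units; within the scatter), stayed within the scatter, so the three compounds show that the number depends on which group sits there and that not every six-membered aromatic ring on that carbon separates from hydrogen: 4-methoxyphenyl does and pyridin-2-yl does not. No measurement among the data shown accounts for this difference.

The exchange of pyridin-2-yl for 4-methoxyphenyl alters both the ring atoms and the substituent at once, so these compounds cannot say whether the step belongs to the carbon-only ring or to the methoxy group. From the compounds shown here alone, how a 4-hydroxyphenyl group, a 4-aminophenyl group or a longer alkyl chain on the same carbon would compare with compound 2 and compound 4 also remains open.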